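Swapping one ring for another: expected solubility of compound 3

The source may hold more compounds than are shown below. What is called first, only, known or untested is meant among the compounds shown, and "the series" means these compounds.

Compound 1, `Cc1ccc(NC(=O)c2cc(Oc3ccc(S(C)(=O)=O)cc3)cc(OC(C)C)c2)nc1`: 1400 nM
Compound 2, `CC(C)Oc1cc(Oc2ccc(S(C)(=O)=O)cc2)cc(-c2cccc(=O)[nH]2)c1`: 11000 nM

Going by the values given here, in a physicochemical assay for solubility, in phosphate buffer, measured as kinetic solubility, with a stated time of 24 h, at pH 6.5 (a higher number here means a more soluble compound, a lower number a less soluble compound), compound 2 gives 11000 nM, the higher of the two numbers measured; the only measured step, a 7.9-fold higher number from compound 1 to compound 2 (0.90 log units; beyond the scatter), separates it from compound 1. Compound 3, `CC(C)Oc1cc(Oc2ccc(S(C)(=O)=O)cc2)cc(-c2cncc(=O)[nH]2)c1`, differs from compound 2 in one place: a group of 7 heavy atoms (4 carbon, 2 nitrogen, 1 oxygen; one six-membered aromatic ring with 2 hetero atoms) in place of a group of 7 heavy atoms (5 carbon, 1 nitrogen, 1 oxygen; one six-membered aromatic ring with 1 hetero atom), on an aromatic carbon. Among the compounds with values here, the measured step concerns a different exchange, so no measured step bears directly on this change, and only a small step, if any beyond the scatter, is expected, estimated as a 1.4-fold higher number from compound 2 to compound 3 (0.13 log units; within the scatter). Compound 3 is therefore expected to give about 15000 nM, within a range from 6000 nM to 40000 nM.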

Compound 3, solubility: 118000 nM
The estimate for compound 3 lay 7.9-fold (0.90 log units) below the measured number; measured number above the stated range.
By their numbers in this assay, from the lowest: compound 1; then compound 2; then compound 3.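

At this position, on an aromatic carbon meta to an isopropoxy group, a change that keeps the heavy-atom count and only trades a ring carbon for a nitrogen gives an 11-fold higher number from compound 2 to compound 3 (1.03 log units; beyond the scatter) in this assay. Thus a small edit to the ring can matter as much as the larger exchange, and together the two changes give an 84-fold higher number from compound 1 to compound 3 (1.93 log units; beyond the scatter). No supporting measurement gives a cause for this jump.

On these data alone, it remains open whether the added nitrogen would have the same effect elsewhere in the ring. Also open, as far as these compounds go, is how an amine or a carboxylic acid on this ring would compare.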